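Methoxy to Hydroxy on a Scaffold at the Tolerance Limit

This account rests on a few compounds, and the source may have more. Where it says the series, first, only, none or still open, it means among the compounds named here.

Three compounds have been measured in a functional assay on SF-268 cells (Homo sapiens) for inhibition, read by sulforhodamine B assay, with a stated time of 48 h; a lower number here means that less compound is tolerated, a higher number that more compound is tolerated:
Compound 1, `O=C(Nc1cccc(-n2cc(-c3ccncc3)c(-c3ccc(Cl)c(O)c3)n2)c1)Nc1cccc(C(F)(F)F)c1`: > 32500 nM
Compound 2, `COc1cc(-c2nn(-c3cccc(NC(=O)Nc4cc(C(F)(F)F)cc(C(F)(F)F)c4)c3)cc2-c2ccncc2)ccc1Cl`: > 50000 nM
Compound 3, `COc1cc(-c2nn(-c3cccc(NC(=O)Nc4cccc(C(F)(F)F)c4)c3)cc2-c2ccncc2)ccc1Cl`: 50000 nM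

Compound 2 stands at a limit of this assay: the value > 50000 nM for compound 2 is a limit, not a number, as stated in the limit of > 50000 nM in this assay, at which 1 of the 3 values shown sits. Compound 1 also sits at a limit, (the limit of > 32500 nM in this assay, at which 1 of the 3 values shown sits), so the step that the limit leaves unreadable from compound 1 to compound 3 cannot be read. Going by these compounds, the step of a number no higher from compound 2 to compound 3 (the limit leaves the size open) is likewise open in size; only compound 3 gives a plain number, 50000 nM.

Compound 4, `O=C(Nc1cccc(-n2cc(-c3ccncc3)c(-c3ccc(Cl)c(O)c3)n2)c1)Nc1cc(C(F)(F)F)cc(C(F)(F)F)c1`, differs from compound 2 in one place: hydrogen in place of methyl on an oxygen on an aromatic ring. The closest measured comparison is the step from compound 1 to compound 3, the same change run the other way, and it too is hidden by a limit. Nothing measured points to a readable step in either direction, so compound 4 is expected to stay near the limit, with a number no higher from compound 2 to compound 4 (the limit leaves the size open) amounting to no change beyond the scatter. Compound 4 is therefore estimated at 50000 nM, within 20000 nM to 120000 nM.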

Compound 4, concentration lethal to 50% of the cells: 20500 nM
For compound 4 the middle estimate is 2.4-fold (0.39 log units) above the measured one; low and high end bracket the measured number.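

Compound 4 gives the first readable trace of the methoxy to hydroxy change: in this assay that exchange gives an at least 2.4-fold lower number from compound 2 to compound 4 (0.38 log units; beyond the scatter), so with two trifluoromethyl groups on the urea's outer ring, the hydroxy compound is tolerated less than the limit of its methoxy partner allows. With hydroxy in place, trifluoromethyl in place of hydrogen on an aromatic carbon gives an at least 1.5-fold lower number from compound 1 to compound 4 (0.20 log units; that floor lies within the scatter), so this second step does not yet establish a real difference. The earlier steps still cannot be read, and comparing this trifluoromethyl change across the methoxy and hydroxy compounds settles nothing: the same change on two cores in this assay, a number no higher (the limit leaves the size open) from compound 2 to compound 3 and an at least 1.5-fold higher number (0.20 log units; that floor lies within the scatter) from compound 4 to compound 1; the limit leaves it open whether they differ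

Going by these compounds, the true size of both new steps stays open, as each starts from a limit. Also open, on these data alone, is how an amine or an ethoxy group in place of the hydroxy would read in this assay.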